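The source may hold more compounds than are shown below. What is called first, only, known or untested is meant among the compounds shown, and "the series" means these compounds.

Of the compounds shown here, three have been measured in a functional assay on cells (Cancer cell lines, Homo sapiens) for inhibition; on this read-out higher numbers stand for weaker inhibition of growth and lower numbers for stronger inhibition of growth. Compound 2 `O=Cc1c(-c2ccc([N+](=O)[O-])cc2)nc2sc(Cc3ccccc3)nn12` gives 4100 nM, the lowest of the three numbers. Within the data shown here, compound 3 `O=[N+]([O-])c1ccc(-c2nc3sc(Cc4ccccc4)nn3c2Br)cc1` gives 6300 nM, and the step of a 1.5-fold higher number from compound 2 to compound 3 (0.19 log units; within the scatter) is the only measured step that changes one place. Compound 1 `N#CSc1c(-c2ccccc2)nc2sc(Cc3ccccc3)nn12` gives 9800 nM, a gap from compound 2 that lies beyond the scatter. Compound 4 `O=Cc1c(-c2ccc(Br)cc2)nc2sc(Cc3ccccc3)nn12` has not been measured; it differs from compound 2 by bromo in place of nitro on an aromatic carbon. Among the measured compounds shown here, no measured step covers this change; the one measured step, bromo in place of formyl, stayed within the scatter. For compound 4 in this assay no step beyond the scatter is therefore expected. Compound 4 is estimated at 5000 nM, within a range from 2000 nM to 13000 nM. This expectation amounts to a 1.2-fold higher number from compound 2 to compound 4 (0.09 log units; within the scatter).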

Compound 4, concentration for 50% growth inhibition: 4200 nM
Compound 4: middle estimate off by 1.2-fold (0.08 log units), on the high side; low and high end bracket the measured number.
By their numbers in this assay, from the lowest: compounds 2, 4, 3 and 1 (each within the scatter of the next, the first and the last beyond it).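

In this assay, putting bromo in place of nitro on the six-membered aromatic ring, para to a large group, gives a 1.0-fold higher number from compound 2 to compound 4 (0.01 log units; within the scatter), with the formyl group and the rest of the core unchanged. Unlike the earlier step at the formyl place, this one tests the aromatic ring itself, and on this read-out the nitro group is not required for the growth inhibition seen with compound 2. Nothing available explains why the two groups read alike. Going by these compounds, whether an amine or a carboxylic acid at this place would read the same remains open. So does whether a methoxy group would.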